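Chloro for cyano on the aryloxyacetic acid series

A few compounds are considered here, and "the series" means these few. Any claim that something is new, unique, unknown or untested is made for them only; others in the source may bear on it.

Measured compounds:
compound 1 `Cc1ccc(S(=O)(=O)N(C)CC(C)C)cc1C#Cc1cc(Cl)ccc1OCC(=O)O` 4.2 nM
compound 2 `CC(C)c1ccc(S(C)(=O)=O)cc1C#Cc1cc(C#N)ccc1OCC(=O)O` 12 nM
compound 3 `CNS(=O)(=O)c1ccc(C)c(C#Cc2cc(Cl)ccc2OCC(=O)O)c1` 10 nM

In an assay on CHO cells for displacement of a labelled ligand from prostaglandin D2 receptor 2 (Homo sapiens), read by scintillation counting (a lower number here means a stronger inhibitor, a higher number a weaker inhibitor), compound 2 gives the highest of the three numbers; compound 3 stands nearest, within the scatter, and compound 1 lies furthest, beyond the scatter. Among the compounds with values here, the one step measured in this assay, a 2.4-fold higher number from compound 1 to compound 3 (0.38 log units; beyond the scatter), concerns hydrogen in place of isobutyl on a sulfonamide nitrogen and does not touch the position changed here.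

Compound 4 `CC(C)c1ccc(S(C)(=O)=O)cc1C#Cc1cc(Cl)ccc1OCC(=O)O` differs from compound 2 by chloro in place of cyano on an aromatic carbon. Within the data shown here, no measured step bears on this exchange. Compounds 1 and 3, which carry chloro at that carbon, both give lower numbers than compound 2, but they also differ from compound 2 at the sulfonyl group and at the alkyl group, so those values cannot be assigned to the chloro alone. For compound 4 a small move to a lower number, or none beyond the scatter, is expected: a 1.7-fold lower number from compound 2 to compound 4 (0.23 log units; within the scatter). The estimated value for compound 4 in this assay is 7 nM, with a range from 3 nM to 18 nM.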

Compound 4, inhibition constant: 4.6 nM
The estimate for compound 4 lay 1.5-fold (0.18 log units) above the measured number, within the range that was stated.
By their numbers in this assay, from the lowest: compounds 1 and 4 (each within the scatter of the next); then compounds 3 and 2 (each within the scatter of the next).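

At the aromatic carbon para to a carboxymethoxy group, with the rest of compound 2 held fixed, chloro in place of cyano now has a direct reading in this assay: a 2.6-fold lower number from compound 2 to compound 4 (0.42 log units; beyond the scatter). The step is modest but beyond the scatter, so this carbon responds to the exchange alone, which compounds 1 and 3 could not show, as each differs from compound 2 in more than one place. Nothing measured here accounts for the step.

Compounds 1 and 3 have no cyano partner among the compounds shown, so the size of this exchange is known on one background only. From the compounds shown here alone, how a fluoro, methoxy or trifluoromethyl group would read at this carbon also stays open.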